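The compounds below may be only part of what the source reports. "The series", "measured", "known", "first", "only" and "open" are said of these compounds alone.

Compound 1 `CCCCCCCCCCCOc1ccccc1CCC(=O)OCCCOP(=O)(O)OC[C@H](N)C(=O)O`: 0.04
Compound 2 `N[C@@H](COP(=O)(O)OCCCOC(=O)CCc1ccccc1OCc1cccc(Oc2cccc(Cl)c2)c1)C(=O)O`: 0.53

Of the compounds shown here, two have been measured in an assay on cells for activation of probable G-protein coupled receptor 34 (Mus musculus), with a stated time of 1 h; on this read-out higher numbers stand for larger maximal responses and lower numbers for smaller maximal responses. Compound 2 stands at the top of the two numbers, giving 0.53 in this assay. Compound 1, the nearest of the two, gives 0.04 in this assay, and the gap between the two values lies beyond the usual scatter of repeated measurements. Among the measured compounds shown here, no pair of measured compounds differs in a single place, so no measured step is available to guide the next change.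

Compound 3 `CC(C)(C)c1cccc(Oc2cccc(COc3ccccc3CCC(=O)OCCCOP(=O)(O)OC[C@H](N)C(=O)O)c2)c1` has not yet been measured. It differs from compound 2 by tert-butyl in place of chloro on an aromatic carbon. For the measured compounds named here, nothing among the measured compounds reads directly on this change, so any expectation for it rests only on the standing of compound 2.

Compound 3 is expected to give about 0.5 in this assay, with a plausible range from 0.25 to 0.8. The step is expected to be a number 0.030 lower from compound 2 to compound 3 (within the scatter), which is to say no change beyond the scatter, in either direction, is anticipated with confidence.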

Compound 3, intrinsic activity: the largest response reached, as a fraction of the reference agonist's: 0.39
The estimate for compound 3 lay 0.11 above the measured number, and the stated range covers the measured number.
By their numbers in this assay, from the lowest: compound 1; then compound 3; then compound 2.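

In this assay, among the compounds shown here, the change from 3-chlorophenoxy to 3-(tert-butyl)phenoxy gives the first measured step at this position, a number 0.14 lower from compound 2 to compound 3 (beyond the scatter), so the read-out does respond to the group placed here, though only modestly. The position accepts tert-butyl, with four heavy atoms in place of the single chlorine, without the response being lost, as compound 3 still gives 0.39 in this assay. No measurement on these compounds offers an explanation for the step.

The compounds shown leave open whether a methyl, a methoxy or a trifluoromethyl group at this same place would read closer to compound 2 or to compound 3, and so whether the number of heavy atoms in the entering group follows the response at all, since a single step cannot separate that from the identity of the group. They also leave open whether the same exchange of chloro for tert-butyl would give a similar step on another aromatic carbon of this ring.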